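Swapping Bromo for Phenethyl: What to Expect

A few compounds are considered here, and "the series" means these few. Any claim that something is new, unique, unknown or untested is made for them only; others in the source may bear on it.

Measured so far in an assay on CHO cells for inhibition of 1,25-dihydroxyvitamin D(3) 24-hydroxylase, mitochondrial (Homo sapiens); on this read-out lower numbers stand for stronger inhibition and higher numbers for weaker inhibition:
compound 1 `COc1ccc2c(c1)CCC(Cc1ccccc1C(F)(F)F)C2=O` gives 2080 nM
compound 2 `COc1ccc2c(c1)CCC(Cc1ccccc1Br)C2=O` gives 16300 nM

Of the two numbers in hand, compound 2 stands at the higher one, meaning weaker inhibition. Within the data shown here, the single measured step, a 7.8-fold higher number from compound 1 to compound 2 (0.89 log units; beyond the scatter), shows that exchanging the trifluoromethyl for bromo on the aromatic carbon pushed the number up beyond the scatter.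

Compound 3 `COc1ccc2c(c1)CCC(Cc1ccccc1CCc1ccccc1)C2=O` differs from compound 2 by phenethyl in place of bromo on an aromatic carbon. Among the measured compounds shown here, the one step that bears on this change concerns the same aromatic carbon, but it exchanged two small groups, and neither measured compound carries a group as large as phenethyl, so the guide is loose. A modest move toward a lower number seems the more likely outcome, with wide uncertainty. For compound 3 in this assay the expected value is 5000 nM, with a range from 800 nM to 30000 nM. This estimate corresponds to a step of a 3.3-fold lower number from compound 2 to compound 3 (0.51 log units; beyond the scatter).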

Compound 3, half-maximal inhibitory concentration: 25600 nM
Compound 3: the middle estimate sits 5.1-fold (0.71 log units) below what was measured; the range from low to high includes it.
By their numbers in this assay, from the lowest: compound 1; then compounds 2 and 3 (each within the scatter of the next).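

In this assay, phenethyl in place of bromo gives a 1.6-fold higher number from compound 2 to compound 3 (0.20 log units; within the scatter), so this aromatic carbon can carry a group with a whole extra ring and far more heavy atoms without a readable difference from bromo. Measured against trifluoromethyl, the same group gives a 12-fold higher number from compound 1 to compound 3 (1.09 log units; beyond the scatter), which leaves compound 1 with the lowest number of the three, and its steps to both other compounds lie beyond the scatter. Nothing available here accounts for either result.

From the compounds shown here alone, it remains open whether an amine, a carboxylic acid or a simple methoxy group on this carbon would match or improve on trifluoromethyl. It is also unknown whether a chain shorter or longer than phenethyl, such as benzyl or phenylpropyl, would read differently from compound 3.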